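Nitro Substitution on the Second Phenyl of Compound 2

A few compounds are considered here, and "the series" means these few. Any claim that something is new, unique, unknown or untested is made for them only; others in the source may bear on it.

Measured so far:
Compound 1, `O=C1NC(=O)/C(=C/c2cn(-c3ccccc3)nc2-c2ccccc2)S1`, gives 8000 nM.
Compound 2, `O=C1NC(=O)/C(=C/c2cn(-c3ccccc3)nc2-c2ccc(Cl)cc2)S1`, gives 800 nM.

Both numbers come from a functional assay on HL-60 cells (Homo sapiens) for inhibition, read by chemiluminescence, with a stated time of 7 days; on this read-out higher numbers stand for weaker inhibition and lower numbers for stronger inhibition. Within the data shown here, on the two values shown, compound 2 stands lowest, and the single step, a 10-fold lower number from compound 1 to compound 2 (1.00 log units; beyond the scatter), separates it from compound 1.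

Compound 3, `O=C1NC(=O)/C(=C/c2cn(-c3ccc([N+](=O)[O-])cc3)nc2-c2ccc(Cl)cc2)S1`, is not yet measured. It differs from compound 2 by nitro in place of hydrogen on an aromatic carbon; cut one bond further out, the change reads phenyl to 4-nitrophenyl.

Among the measured compounds shown here, no measured step touches this ring: the only step available, a 10-fold lower number from compound 1 to compound 2 (1.00 log units; beyond the scatter), concerns the other phenyl. It shows that a substituent on one of the two outer rings can shift the number, but it says nothing about this ring or about a nitro group. The expectation for compound 3 is therefore a step of a 1.6-fold lower number from compound 2 to compound 3 (0.20 log units; within the scatter), with wide uncertainty. Compound 3 is expected to give about 500 nM, within a range of 150 nM to 2500 nM in this assay.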

Compound 3, half-maximal inhibitory concentration: 1000 nM
Compound 3: the middle estimate sits 2.0-fold (0.30 log units) below what was measured, and the stated range covers the measured number.
By their numbers in this assay, from the lowest: compounds 2 and 3 (each within the scatter of the next); then compound 1.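

Turning phenyl into 4-nitrophenyl, on a ring that no earlier step had touched, gave a 1.3-fold higher number from compound 2 to compound 3 (0.10 log units; within the scatter) in this assay. This position therefore takes a nitro group, with its 3 heavy atoms, without a change that can be told from the scatter. That differs from the chloro change on the other phenyl, which gave a 10-fold lower number from compound 1 to compound 2 (1.00 log units; beyond the scatter), so a substituent on an outer ring of this series does not shift the number in every case, and no data at hand explain this result.

The compounds shown leave open what an amine, a carboxylic acid or a methoxy group would do at this same place on the ring. They also leave open whether nitro gives a similar result on the core of compound 1, without the chloro.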